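The source may hold more compounds than are shown below. What is called first, only, known or untested is meant among the compounds shown, and "the series" means these compounds.

In an ADME assay on Huh-7 cells (Homo sapiens) for cytotoxicity, read by thymidine incorporation (on this read-out higher numbers stand for lower toxicity in this test and lower numbers for higher toxicity in this test), compound 1 `COC(=O)N[C@H](C(=O)N1CCC[C@H]1c1nc2cc(-c3ccc(-c4ccc5[nH]c([C@@H]6CCCN6C(=O)[C@@H](NC(=O)OC)C(C)C)nc5c4)c(C)c3)ccc2[nH]1)C(C)C` gives 3000 nM while compound 2 `COC(=O)N[C@H](C(=O)N1CCC[C@H]1c1nc2cc(-c3ccc(-c4ccc5[nH]c([C@@H]6CCCN6C(=O)[C@@H](NC(=O)OC)C(C)C)nc5c4)c(OC)c3)ccc2[nH]1)C(C)C` gives 6000 nM and compound 3 `COC(=O)N[C@H](C(=O)N1CCC[C@H]1c1nc2cc(-c3cc(C)c(-c4ccc5[nH]c([C@@H]6CCCN6C(=O)[C@@H](NC(=O)OC)C(C)C)nc5c4)cc3C)ccc2[nH]1)C(C)C` gives 5000 nM in the same test, so compound 1 stands within the scatter of both. Compound 4 `COC(=O)N[C@H](C(=O)N1CCC[C@H]1c1nc2cc(-c3ccc(-c4ccc5[nH]c([C@@H]6CCCN6C(=O)[C@@H](NC(=O)OC)C(C)C)nc5c4)c(C)c3C)ccc2[nH]1)C(C)C` differs from compound 1 by methyl in place of hydrogen on an aromatic carbon and the new methyl stands ortho to a methyl group. Methyl in place of hydrogen on an aromatic carbon elsewhere gave a 1.7-fold higher number from compound 1 to compound 3 (0.22 log units; within the scatter) and methoxy in place of methyl gave a 2.0-fold higher number from compound 1 to compound 2 (0.30 log units; within the scatter) (both within the scatter). In this assay no step beyond the scatter is therefore expected, and the estimated step is a 1.3-fold higher number from compound 1 to compound 4 (0.12 log units; within the scatter) at its middle. The expected value for compound 4 is 4000 nM (estimated range 1800 nM to 9000 nM).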

Compound 4, half-maximal cytotoxic concentration: 7000 nM
Beside the measured number, compound 4's estimate is 1.8-fold (0.24 log units) below it; the range from low to high includes it.
By their numbers in this assay, from the lowest: compounds 1, 3, 2 and 4 (each within the scatter of the next, the first and the last beyond it).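

Methyl in place of hydrogen at this position, ortho to a methyl group, gives a 2.3-fold higher number from compound 1 to compound 4 (0.37 log units; beyond the scatter) in this assay and is the only step in the series that passes the scatter. Methyl in place of hydrogen at the other place gives a 1.7-fold higher number from compound 1 to compound 3 (0.22 log units; within the scatter) and does not, so on this read-out the outcome of this change differs with its place. Nothing at hand accounts for this modest step.

Still open, as far as these compounds go, is whether the step needs the methyl group to which the new methyl stands ortho. Also open, from the compounds shown here alone, is whether ethyl or an amine on this aromatic carbon would move the number in the same direction.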